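This account rests on a few compounds, and the source may have more. Where it says the series, first, only, none or still open, it means among the compounds named here.

Compound 1 `NC(=O)CNC(=O)c1cccc(-c2cccc3cc(Cc4cccc(C(F)(F)F)c4)sc23)c1` gives 55 nM in a functional assay on CHO cells for agonist activity at G-protein coupled receptor 52 (Homo sapiens), read by AlphaScreen and cAMP accumulation, with a stated time of 30 min (a lower number here means that less compound is needed, a higher number that more compound is needed for the effect), the higher of the two numbers recorded so far, although compound 2 `COCCNC(=O)c1cccc(-c2cccc3cc(Cc4cccc(C(F)(F)F)c4)sc23)c1` gives 42.7 nM and the step of a 1.3-fold lower number from compound 1 to compound 2 (0.11 log units; within the scatter) lies within the scatter. Compound 3 `NC(=O)CNC(=O)c1cccc(-c2ccc(F)c3cc(Cc4cccc(C(F)(F)F)c4)sc23)c1` differs from compound 1 by fluoro in place of hydrogen on an aromatic carbon. Within the data shown here, the only measured step concerns the amide substituent and not the fused ring, so no measured step bears on this change. Compound 3 is therefore expected to show no change at the digits printed from compound 1 to compound 3 (within the scatter), nothing beyond the scatter. Compound 3 is estimated at 55 nM, with a range from 20 nM to 150 nM.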

Compound 3, half-maximal effective concentration: 83.2 nM
Compound 3: the middle estimate sits 1.5-fold (0.18 log units) below what was measured, and the stated range covers the measured number.
By their numbers in this assay, from the lowest: compounds 2, 1 and 3 (each within the scatter of the next).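

On the aromatic carbon para to a large group, fluoro in place of hydrogen gives a 1.5-fold higher number from compound 1 to compound 3 (0.18 log units; within the scatter) in this assay. Among these compounds, this is the first look at the fused ring system, and this position accepts a fluorine atom with no difference that can be told from the scatter. Nothing measured here bears on the reason for this result. The compounds shown leave open whether chloro, methoxy or a nitrile at this carbon would also stay within the scatter. They also leave open how fluoro here would read with the amide chain of compound 2.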